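Swapping an amide for a carbamate on the chain

The source may hold more compounds than are shown below. What is called first, only, known or untested is meant among the compounds shown, and "the series" means these compounds.

Of the compounds shown here, two sharing one core have been measured in an assay on H4 cells for inhibition of Fatty-acid amide hydrolase 1 (Homo sapiens); a lower number here means a stronger inhibitor, a higher number a weaker inhibitor. Compound 1, `CCOC(=O)CC(CC)CCCCCn1c(C)nc(-c2ccccc2)c1-c1ccccc1`, gives 9900 nM. Compound 2, `Cc1nc(-c2ccccc2)c(-c2ccccc2)n1CCCCCCC(=O)N(C)C`, gives 970 nM. Among the compounds with values here, the single measured step, a 10-fold lower number from compound 1 to compound 2 (1.01 log units; beyond the scatter), came from putting (dimethylcarbamoyl)methyl in place of 1-((ethoxycarbonyl)methyl)propyl on a saturated chain carbon, five bonds along the chain from an aromatic nitrogen. Compound 2 therefore holds the lowest number of the two.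

Compound 3, `Cc1nc(-c2ccccc2)c(-c2ccccc2)n1CCCCCCNC(=O)Oc1ccccc1`, keeps the core and the chain of compound 2 but alters its end: (phenoxycarbonyl)amino in place of dimethylcarbamoyl on a saturated chain carbon, six bonds along the chain from an aromatic nitrogen. Within the data shown here, no measured step covers this change; the step from compound 1 to compound 2 concerns a different pair of groups, so it says only that the end of the chain can move this assay a great deal. The direction here is open. For compound 3 a step of a 4.9-fold lower number from compound 2 to compound 3 (0.69 log units; beyond the scatter) is expected, which means an estimate of 200 nM in this assay, with a plausible range from 20 nM to 2000 nM.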

Compound 3, half-maximal inhibitory concentration: 5.3 nM
For compound 3 the middle estimate is 38-fold (1.58 log units) above the measured one; measured number below the stated range.
By their numbers in this assay, from the lowest: compound 3; then compound 2; then compound 1.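

The change at the chain end carries far more weight in this assay than the first pair could show: it gives a 180-fold lower number from compound 2 to compound 3 (2.26 log units; beyond the scatter), and the direction left open before is now settled for this pair. Set against compound 1, the gap grows to a 1900-fold lower number from compound 1 to compound 3 (3.27 log units; beyond the scatter), so changes at the end of this chain alone span the whole range of numbers seen so far, on an unchanged core. The entering (phenoxycarbonyl)amino group differs from dimethylcarbamoyl in several ways at once, adding a six-membered aromatic ring of carbon only and a hydrogen-bond donor, and nothing available here explains why the number falls so far.

These compounds do not separate the contribution of the phenyl ring from that of the link joining it to the chain, as both enter together. A phenylurea end, with a nitrogen in place of the oxygen that carries the ring, or a plain amine at the chain end, would test each part, and a longer chain bearing the same (phenoxycarbonyl)amino group would show how much the chain length matters.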